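Replacing Phenyl with Cyclohexyl: What to Expect

The source may report more compounds than this note shows. Statements on the series, on what has been measured and on what is new or still open speak of the compounds shown alone.

Of the compounds shown here, two sharing one core have been tested in an ADME assay on CHO cells (Cricetulus griseus) for cytotoxicity; a higher number here means a weaker inhibitor, a lower number a stronger inhibitor. Compound 1 `O/N=C(\c1cnccn1)c1nc2ccccc2s1` carries a pyrazin-2-yl group on a carbon with a double bond to nitrogen, and in this assay compound 1 gives 11700 nM. Compound 2 `O/N=C(\c1ccccc1)c1nc2ccccc2s1` carries a phenyl group at that carbon instead. In this assay compound 2 reaches only the limit of the assay, > 100000 nM, so its true number is not known. The step of an at least 8.5-fold higher number from compound 1 to compound 2 (0.93 log units; beyond the scatter) is thus only a floor on the weakening, as shown by the limit of > 100000 nM in this assay, at which 1 of the 2 values shown sits.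

Compound 3 `O/N=C(/c1nc2ccccc2s1)C1CCCCC1` is not yet measured. It differs from compound 2 by cyclohexyl in place of phenyl on a carbon with a double bond to nitrogen. Within the data shown here, no measured step exchanges an aromatic ring for a saturated one at this carbon, so the only guide is an at least 8.5-fold higher number from compound 1 to compound 2 (0.93 log units; beyond the scatter), where a change at this same carbon moved the number up to the limit. Compound 2 already sits at that limit, so little further movement can be resolved. The step of a number no higher from compound 2 to compound 3 (the limit leaves the size open) is expected to be small or unmeasurable. The estimate for compound 3 in this assay is 100000 nM, within a range from 30000 nM to 300000 nM, with a real chance that only a limit is reported again.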

Compound 3, half-maximal inhibitory concentration: 51600 nM
Estimate against measurement, compound 3: 1.9-fold (0.29 log units) above; measured number inside the range.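

In this assay, the carbon with a double bond to nitrogen now has a step of known size: with cyclohexyl in place of pyrazin-2-yl there is a 4.4-fold higher number from compound 1 to compound 3 (0.64 log units; beyond the scatter) and not merely a floor. A six-membered ring of carbon only at this position therefore does not always take the number to the limit, since the non-aromatic ring of compound 3 gives a measured number while the aromatic ring of compound 2 does not. On these data alone, whether these two rings truly differ cannot be settled, with an at least 1.9-fold lower number from compound 2 to compound 3 (0.28 log units; that floor lies within the scatter) as a floor that lies within the scatter, and the true number of compound 2 remains unknown because of this: the limit of > 100000 nM in this assay, at which 1 of the 3 values shown sits.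

The compounds shown leave open whether the nitrogen atoms of pyrazin-2-yl matter here, which a pyridin-2-yl ring with a single ring nitrogen could begin to test. They also leave open where an open chain such as n-butyl, or a ring carrying an amine such as piperidin-4-yl, would fall at this carbon.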